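Chain extension on the aryl ether of the shared core

The source may report more compounds than this note shows. Statements on the series, on what has been measured and on what is new or still open speak of the compounds shown alone.

Measured compounds:
compound 1 `CCOc1c(-c2cc(OC)c(OC)c(OC)c2)oc2ccccc2c1=O`: 900 nM
compound 2 `CCCOc1c(-c2cc(OC)c(OC)c(OC)c2)oc2ccccc2c1=O`: 11800 nM

In a functional assay on PC-3 cells (Homo sapiens) for antiproliferative activity, read by WST assay, with a stated time of 3 days (on this read-out higher numbers stand for weaker inhibition and lower numbers for stronger inhibition), compound 1 gives 900 nM, and compound 2 gives 11800 nM. Going by the values given here, compound 2 therefore stands at the weaker end of the two numbers, the only step to it being a 13-fold higher number from compound 1 to compound 2 (1.12 log units; beyond the scatter).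

Compound 3 `CCCCCCOc1c(-c2cc(OC)c(OC)c(OC)c2)oc2ccccc2c1=O` is not yet measured. Its difference from compound 2 is propyl in place of hydrogen on a saturated chain carbon, three bonds along the chain from an oxygen on an aromatic ring. Among the compounds with values here, the one step that bears on it is a 13-fold higher number from compound 1 to compound 2 (1.12 log units; beyond the scatter), a large loss on lengthening the chain on the oxygen on the aromatic ring. Within the data shown here, the change to compound 3 lengthens that same chain further, by a propyl, so a further step toward weaker inhibition in this assay is expected, possibly of comparable or larger size, though only one step supports this.

For compound 3 in this assay the expected value is 40000 nM, within 12000 nM to 150000 nM, which means an expected step of a 3.4-fold higher number from compound 2 to compound 3 (0.53 log units; beyond the scatter).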

Compound 3, half-maximal inhibitory concentration: 29200 nM
Beside the measured number, compound 3's estimate is 1.4-fold (0.14 log units) above it; the range from low to high includes it.
By their numbers in this assay, from the lowest: compound 1; then compound 2; then compound 3.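

In this assay the further lengthening by propyl moves the same way as the first extension, with a 2.5-fold higher number from compound 2 to compound 3 (0.39 log units; beyond the scatter) against the earlier 13-fold higher number from compound 1 to compound 2 (1.12 log units; beyond the scatter); the second step is the smaller, though the added chain is longer. Taken whole, the change amounts to a 32-fold higher number from compound 1 to compound 3 (1.51 log units; beyond the scatter), so the numbers rise in chain order across all three compounds, with none going against that order, and the ethyl chain of compound 1 gives the lowest number. Nothing on hand explains why the numbers rise with chain length or why the second step is smaller.

On these data alone, whether a methyl on this oxygen would give a lower number than compound 1 remains open. So does whether a chain longer than hexyl, or one ending in an amine, would continue the rise.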